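This account rests on a few compounds, and the source may have more. Where it says the series, first, only, none or still open, it means among the compounds named here.

Of the compounds shown here, three have so far been measured in an in vitro assay on Sf21 cells for inhibition of high affinity 3',5'-cyclic-AMP phosphodiesterase 7A (Homo sapiens); on this read-out higher numbers stand for weaker inhibition and lower numbers for stronger inhibition.

- Compound 1 `CNc1nc(NC2(C#N)CCCCC2)nc(-n2cnc(C)n2)n1` gives > 5000 nM, which is a limit of the assay and not a number.
- Compound 2 `CNc1nc(NC2(C#N)CCCCC2)nc(OC)n1` gives 521 nM.
- Compound 3 `CNc1nc(NC2(C#N)CCCCC2)nc(-n2cncn2)n1` gives > 5000 nM, again a limit of the assay rather than a number.

Compound 3 therefore stands at the limit described by the limit of > 5000 nM in this assay, at which 2 of the 3 values shown sit, together with compound 1, and only compound 2 has a measured number. The step of an at least 9.5-fold higher number from compound 2 to compound 3 (0.98 log units; beyond the scatter) is beyond the scatter, and the step of an at least 9.5-fold lower number from compound 1 to compound 2 (0.98 log units; beyond the scatter) points the same way, while a step that the two limits leave unreadable from compound 1 to compound 3 cannot be read because both ends are limits.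

Compound 4 `CNc1nc(NC2CCCC2)nc(NC2(C#N)CCCCC2)n1` differs from compound 3 in one place: cyclopentylamino in place of 1H-1,2,4-triazol-1-yl on an aromatic carbon. The two readable steps both show that taking the triazole away and putting a smaller group in its place lowers the number well beyond the scatter. Going by the values given here, no measured compound carries a cyclopentylamino group, so the size of the change is uncertain. Still, because the step of an at least 9.5-fold higher number from compound 2 to compound 3 (0.98 log units; beyond the scatter) shows the triazolyl group raising the number into the limit, its removal is expected to bring compound 4 back to a measurable value, a step of about an at least 5.5-fold lower number from compound 3 to compound 4 (0.74 log units; beyond the scatter). For compound 4 the expected result in this assay is 900 nM, within a range of 150 nM to 5000 nM.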

Compound 4, half-maximal inhibitory concentration: > 5000 nM
Compound 4 ended at the assay's limit; the forecaster's own chance of this, stated with the estimate: 25%; middle value at least 5.5-fold (0.74 log units) away from the limit.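

In this assay compound 4 gives > 5000 nM, which is a limit of the assay and not a number. Going by these compounds alone, putting cyclopentylamino in place of methoxy on this aromatic carbon, opposite the ring nitrogen, produces an at least 9.5-fold higher number from compound 2 to compound 4 (0.98 log units; beyond the scatter), so the triazolyl groups are no longer the only groups at this position that end far from compound 2: a non-aromatic ring of carbon, attached through an amino nitrogen and carrying a hydrogen-bond donor, does the same. Three quite different groups at this position now share one limit, and methoxy alone gives a measured number: the limit of > 5000 nM in this assay, at which 3 of the 4 values shown sit.

The steps linking compound 1, compound 3 and compound 4 cannot be read, since both ends of each are limits, so any order among these three groups stays unknown, as does how far each lies beyond the limit. From the compounds shown here alone, it also stays open whether the measured number depends on something particular to methoxy, which an ethoxy group, a hydroxyl group, a plain amino group or a dimethylamino group at the same position could help to show.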